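Replacing a methoxyphenyl group within a growth-inhibition series

This account rests on a few compounds, and the source may have more. Where it says the series, first, only, none or still open, it means among the compounds named here.

This account concerns four related compounds tested on a prostate cancer cell line. Compound 1 `Cc1ccc(CS/C(=C/c2ccc(Br)cc2)C(=O)c2ccc(Cl)cc2)cc1` and compound 2 `COc1ccccc1/C=C(/SCc1ccc(C)cc1)C(=O)c1ccc(Cl)cc1` share a core and differ in one place only. In a functional assay on DU-145 cells (Homo sapiens) for inhibition, read by trypan blue exclusion, with a stated time of 96 h (on this read-out lower numbers stand for stronger inhibition of growth and higher numbers for weaker inhibition of growth), compound 1 gives 10000 nM. In this assay compound 2 gives 10000 nM. Going by the values given here, the one change between them is 4-bromophenyl in place of 2-methoxyphenyl on a double-bonded chain carbon bound to a double-bonded chain carbon, and the step of no change at the digits printed from compound 2 to compound 1 (within the scatter).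

Compound 3 `COc1ccccc1/C=C(\C(=O)c1ccc(Br)cc1)S(=O)(=O)Cc1ccc(F)cc1` belongs to a different core, and how its core differs from that of compound 2 is not broken down here. In this assay compound 3 gives 25000 nM, the highest of the three measured numbers, and its distance from both compound 1 and compound 2 lies beyond the scatter.

Compound 4 `O=C(/C(=C\c1ccc(Br)cc1)S(=O)(=O)Cc1ccc(F)cc1)c1ccc(Br)cc1` is not yet measured. Among the compounds with values here, it arises from compound 3 by 4-bromophenyl in place of 2-methoxyphenyl on a double-bonded chain carbon bound to a double-bonded chain carbon, which is the same change as the one from compound 2 to compound 1: the group that leaves, the group that enters and the place are identical in both pairs. Because the measured step of no change at the digits printed from compound 2 to compound 1 (within the scatter) is flat within the scatter, the expected step from compound 3 to compound 4 is no change at the digits printed from compound 3 to compound 4 (within the scatter), a repetition of that flat result. Compound 4 is therefore estimated to give 25000 nM in this assay, with a range of 10000 nM to 60000 nM expected to cover most repeat measurements. This expectation rests on a single prior instance of the change, so it carries limited weight.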

Compound 4, concentration for 50% growth inhibition: 25000 nM
Estimate against measurement, compound 4: no gap at the digits printed; low and high end bracket the measured number.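

In this assay the new step reads no change at the digits printed from compound 3 to compound 4 (within the scatter), so 4-bromophenyl in place of 2-methoxyphenyl leaves the number as flat on the core of compound 3 as it did on the core of compound 1, and the two steps agree: the same change on two cores in this assay, no change at the digits printed (within the scatter) from compound 2 to compound 1 and no change at the digits printed (within the scatter) from compound 3 to compound 4, 1.0-fold (0.00 log units) apart, within the scatter of two such steps

Within these four compounds, then, the change carries from one core to the other without a difference beyond the scatter, and the flat result on one core was a fair guide to the result on the other. Going by these compounds alone, this does not show that the change would stay flat on any further core, since it rests on only two pairs, and neither pair shows whether a step that really moved the number would also carry over.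

The compounds shown leave open whether any other group at this place, on a double-bonded chain carbon bound to a double-bonded chain carbon, would move the number at all. A phenyl ring bearing an amine or a carboxylic acid, for instance, might answer that, and it might also test whether the two cores still respond alike once a step is larger than the scatter.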